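A few compounds are considered here, and "the series" means these few. Any claim that something is new, unique, unknown or untested is made for them only; others in the source may bear on it.

Compound 1 `Cc1nc(S(C)(=O)=O)ccc1Oc1ncnc(OC2CCN(C(=O)O[C@H](C)C(F)(F)F)CC2)c1F`: 110 nM
Compound 2 `Cc1nc(S(C)(=O)=O)ccc1Oc1ncnc(OC2CCN(C(=O)O[C@@H](C)C(F)(F)F)CC2)c1F`: 109 nM
Compound 3 `Cc1nc(S(C)(=O)=O)ccc1Oc1ncnc(OC2CCN(C(=O)SC3(C)CC3)CC2)c1F`: 166 nM

In a functional assay on isolated protein for inhibition of Glucose-dependent insulinotropic receptor (Rattus norvegicus), read by HTRF and cAMP accumulation (a lower number here means that less compound is needed, a higher number that more compound is needed for the effect), compound 1 gives 110 nM, and its number cannot be told apart from those of the other two compounds within the usual scatter. The step of a 1.0-fold lower number from compound 1 to compound 2 (0.00 log units; within the scatter) is as small as it can be, which fits (the fact that compounds 1 and 2 differ only in the configuration as drawn). The step of a 1.5-fold higher number from compound 1 to compound 3 (0.18 log units; within the scatter) swaps the group on the carbonyl carbon, as does a 1.5-fold higher number from compound 2 to compound 3 (0.18 log units; within the scatter), and both stay within the scatter.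

Compound 4 `Cc1nc(S(C)(=O)=O)ccc1Oc1ncnc(OC2CCN(C(=O)C(C)(C)F)CC2)c1F` is not yet measured. It differs from compound 1 at the same carbonyl carbon: 1-fluoro-1-methylethyl in place of 1-(trifluoromethyl)ethoxy on a carbonyl carbon. Within the data shown here, the only measured guidance for a change at this carbonyl carbon is the step to compound 3, which was within the scatter, so the expected step of a 1.4-fold higher number from compound 1 to compound 4 (0.13 log units; within the scatter) is small and not clearly beyond the scatter, if anything toward a slightly higher number. Compound 4 is therefore expected to give about 150 nM in this assay, with a likely range from 60 nM to 400 nM.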

Compound 4, half-maximal effective concentration: 296 nM
Beside the measured number, compound 4's estimate is 2.0-fold (0.30 log units) below it; low and high end bracket the measured number.
By their numbers in this assay, from the lowest: compounds 2, 1, 3 and 4 (each within the scatter of the next, the first and the last beyond it).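

Unlike the step to compound 3, putting 1-fluoro-1-methylethyl in place of 1-(trifluoromethyl)ethoxy on the carbonyl carbon gives a modest change beyond the scatter in this assay: a 2.7-fold higher number from compound 1 to compound 4 (0.43 log units; beyond the scatter) and, of the same size, a 2.7-fold higher number from compound 2 to compound 4 (0.43 log units; beyond the scatter). The position therefore does respond to the group it carries, though compound 3 and compound 4 still cannot be told apart, with a 1.8-fold higher number from compound 3 to compound 4 (0.25 log units; within the scatter). Nothing in the available facts accounts for this step.

The oxygen and the number of fluorine atoms change together in this step, and the compounds shown do not separate the two. As far as these compounds go, how an amine or a longer chain on the same carbonyl carbon would read also remains open.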